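Swapping the Benzyl Ether Aryl Group: Fluorine to Methyl

This account rests on a few compounds, and the source may have more. Where it says the series, first, only, none or still open, it means among the compounds named here.

Of the compounds shown here, two built on the same core have been measured. Compound 1 `Cc1ccc(NC(=O)NC(=O)c2ccc(OCc3cccc(Cl)c3)cc2)cc1-c1nc2ccccc2[nH]1` gives 16000 nM in a functional assay on SW-620 cells (Homo sapiens) for inhibition, read by MTT assay, with a stated time of 48 h; a higher number here means a weaker inhibitor, a lower number a stronger inhibitor. Among the compounds with values here, compound 2 `Cc1ccc(NC(=O)NC(=O)c2ccc(OCc3ccccc3F)cc2)cc1-c1nc2ccccc2[nH]1` gives 4110 nM in this assay, which is the lowest of the two numbers so far; its nearest neighbour is compound 1, and the single measured step, a 3.9-fold lower number from compound 1 to compound 2 (0.59 log units; beyond the scatter), lies beyond the usual scatter.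

Compound 3 `Cc1ccc(COc2ccc(C(=O)NC(=O)Nc3ccc(C)c(-c4nc5ccccc5[nH]4)c3)cc2)cc1` is not yet measured. It differs from compound 2 in one place: 4-methylphenyl in place of 2-fluorophenyl on a saturated chain carbon bound to an oxygen on an aromatic ring. Within the data shown here, the only measured step that touches this same place is a 3.9-fold lower number from compound 1 to compound 2 (0.59 log units; beyond the scatter), and it shows that changing the aryl group on that chain carbon can move the number by a modest amount. Among the measured compounds shown here, no measured compound carries a 4-methylphenyl there, so nothing in the data fixes the direction of this change; the expectation can only be that the number stays within a modest distance of compound 2. The step expected here is a 1.5-fold higher number from compound 2 to compound 3 (0.16 log units; within the scatter). Compound 3 is therefore estimated to give 6000 nM in this assay, with a likely range from 2000 nM to 20000 nM.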

Compound 3, half-maximal inhibitory concentration: 26000 nM
Compound 3: middle estimate off by 4.3-fold (0.64 log units), on the low side; measured number above the stated range.
By their numbers in this assay, from the lowest: compound 2; then compounds 1 and 3 (each within the scatter of the next).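

In this assay, the 4-methylphenyl group gives a 6.3-fold higher number from compound 2 to compound 3 (0.80 log units; beyond the scatter), so the lower number of compound 2 does not carry over to this other aryl group on the saturated chain carbon. The other comparison, a 1.6-fold higher number from compound 1 to compound 3 (0.21 log units; within the scatter), lies within the scatter, so compound 1 and compound 3 cannot be told apart, even though 3-chlorophenyl and 4-methylphenyl carry different substituents at different ring locations; among these three compounds, only compound 2 stands apart, with both of its steps beyond the scatter, and it is the strongest inhibitor of the set. No supporting measurement accompanies these results to say what lies behind the difference.

The three aryl groups change both the substituent and its location on the ring at once, so these compounds cannot show whether the lower number of compound 2 goes with the fluorine itself or with the 2-fluoro arrangement. From the compounds shown here alone, how an unsubstituted phenyl group, or a phenyl ring bearing a methoxy group or an amine, would compare at this same place also remains open.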